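The source may hold more compounds than are shown below. What is called first, only, known or untested is meant among the compounds shown, and "the series" means these compounds.

Compound 3 `O=C(C1CCC1)N1CC2CC(C1)N2` is the member of this small set that gives the highest number in an assay on CHO cells for agonist activity at Neuronal acetylcholine receptor; alpha3/alpha6/beta2/beta3 (Homo sapiens), read by FLIPR and calcium flux; a lower number here means that less compound is needed, a higher number that more compound is needed for the effect: compound 3 gives 370 nM. Its nearest neighbour is compound 2 `CCCC(=O)N1CC2CC(C1)N2`, which in this assay gives 300 nM, and the two are separated by a 1.2-fold higher number from compound 2 to compound 3 (0.09 log units; within the scatter). Compound 1 `CCC(=O)N1CC2CC(C1)N2` stands furthest away; in this assay compound 1 gives 180 nM, and the step is a 2.1-fold higher number from compound 1 to compound 3 (0.31 log units; beyond the scatter).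

Compound 4 `O=C([C@@H]1C[C@@H]1F)N1CC2CC(C1)N2` has not yet been measured. It differs from compound 3 in one place: 2-fluorocyclopropyl in place of cyclobutyl on a carbonyl carbon. Every measured step in this set changes the group on that same carbonyl carbon. Those steps were a 1.7-fold higher number from compound 1 to compound 2 (0.22 log units; within the scatter), a 2.1-fold higher number from compound 1 to compound 3 (0.31 log units; beyond the scatter) and a 1.2-fold higher number from compound 2 to compound 3 (0.09 log units; within the scatter), so exchanging one small group for another on the carbonyl carbon has so far moved the number only a little, and never beyond a modest amount. Within the data shown here, no compound yet carries a fluorine, so that part of the change has no measured precedent here.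

On that basis compound 4 is expected to land close to compound 3, with at most a modest movement in either direction, estimated as a 1.2-fold lower number from compound 3 to compound 4 (0.09 log units; within the scatter). The estimate for compound 4 in this assay is 300 nM, with a range from 110 nM to 800 nM.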

Compound 4, half-maximal effective concentration: 88 nM
Beside the measured number, compound 4's estimate is 3.4-fold (0.53 log units) above it, outside the stated range (below it).
By their numbers in this assay, from the lowest: compound 4; then compounds 1, 2 and 3 (each within the scatter of the next, the first and the last beyond it).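

In (this assay), the carbonyl carbon proves more responsive than ethyl, propyl and cyclobutyl had suggested: 2-fluorocyclopropyl in place of cyclobutyl gives the largest step seen at this position (a 4.2-fold lower number from compound 3 to compound 4 (0.62 log units; beyond the scatter)), and the same group in place of propyl (a 3.4-fold lower number from compound 2 to compound 4 (0.53 log units; beyond the scatter)) or ethyl (a 2.0-fold lower number from compound 1 to compound 4 (0.31 log units; beyond the scatter)) also gives a lower number, so compound 4 stands lowest of the four with all its steps beyond the scatter. Cyclobutyl and 2-fluorocyclopropyl hold the same count of heavy atoms and neither carries a hydrogen-bond donor or acceptor, so these counts do not separate compound 3 from compound 4, and the difference lies in the ring size, the fluorine and the defined stereocentres. Nothing measured here accounts for the lower number.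

The fluorine and the three-membered ring enter together, so the compounds shown leave open how much each contributes, which plain cyclopropyl or 2-methylcyclopropyl on the same carbonyl carbon could help to separate. Also open, from the compounds shown here alone, is whether the arrangement at the stereocentres matters, as the other stereoisomers of 2-fluorocyclopropyl would show, and how 2,2-difluorocyclopropyl would compare.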